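Triazolylmethyl in place of the lactam alkylidene on compound 1

The source may hold more compounds than are shown below. What is called first, only, known or untested is meant among the compounds shown, and "the series" means these compounds.

Compound 1 `CC(C)C(/C=C1\CCNC1=O)c1ccc(-c2ccc3cccc(F)c3c2)[nH]c1=O` is the stronger of the two measured compounds: in a functional assay on CHO cells for antagonist activity at prostaglandin E2 receptor EP3 subtype (Homo sapiens), read by cAMP accumulation (a higher number here means a weaker inhibitor, a lower number a stronger inhibitor), compound 1 gives 8.7 nM. Compound 2 `CCn1ncc2c(F)cc(-c3ccc(C(CC)(CC)c4nnc[nH]4)c(=O)[nH]3)cc21`, built on a different core and carrying a triazole directly on its chain carbon, gives 29 nM in this assay, a gap that lies beyond the scatter. Compound 3 `CC(C)C(Cc1nnc[nH]1)c1ccc(-c2ccc3cccc(F)c3c2)[nH]c1=O` keeps the core of compound 1 and changes one group: a group of 6 heavy atoms (3 carbon, 3 nitrogen; one five-membered aromatic ring with 3 hetero atoms) in place of a group of 7 heavy atoms (5 carbon, 1 nitrogen, 1 oxygen; one five-membered non-aromatic ring with 1 hetero atom), on a saturated chain carbon bound to an aromatic carbon and a saturated chain carbon. Among the compounds with values here, no measured pair shows this change on a shared core, so its size is not known from the numbers here. The triazole of compound 2 sits in a less potent compound, but that compound also differs in core and chain, so it gives only a loose hint. A moderate loss is expected for compound 3, estimated at 22 nM with a range of 7 nM to 70 nM in this assay. The expected step of a 2.5-fold higher number from compound 1 to compound 3 (0.40 log units; beyond the scatter) is likely somewhat beyond the scatter, toward weaker inhibition.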

Compound 3, half-maximal inhibitory concentration: 17 nM
The estimate for compound 3 lay 1.3-fold (0.11 log units) above the measured number, within the range that was stated.
By their numbers in this assay, from the lowest: compounds 1, 3 and 2 (each within the scatter of the next, the first and the last beyond it).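

On a saturated chain carbon bound to an aromatic carbon and a saturated chain carbon, exchanging the group of 7 heavy atoms for (4H-1,2,4-triazol-3-yl)methyl gives a 2.0-fold higher number from compound 1 to compound 3 (0.29 log units; within the scatter) in this assay. On the core of compound 1, this position therefore accepts a five-membered aromatic ring with 3 hetero atoms in place of a five-membered non-aromatic ring with 1 hetero atom, and the 2 double bonds outside aromatic rings are not needed to stay within the scatter. Nothing measured on these compounds accounts for this result.

On these data alone, it remains open how a carboxylic acid, an amine or a tetrazole would read at this position, or a longer chain leading to the triazole. Compound 2 differs from compound 3 in more than one place, so the separate contributions of its core and chain cannot be read.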